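Swapping methoxy for fluoro on the distal aryl ring

This account rests on a few compounds, and the source may have more. Where it says the series, first, only, none or still open, it means among the compounds named here.

Measured compounds, with their numbers in an assay on CHO cells for displacement of a labelled ligand from 5-hydroxytryptamine receptor 7 (Homo sapiens); a higher number here means a weaker inhibitor, a lower number a stronger inhibitor:
- compound 1 `CCC1(CCCCN2CCN(c3cccc(Cl)c3)CC2)C(=O)Nc2ccccc21`: 0.41 nM
- compound 2 `CCC1(CCCCN2CCN(c3ccc(F)cc3)CC2)C(=O)Nc2ccc(F)cc21`: 1.5 nM
- compound 3 `CCC1(CCCCN2CCN(c3ccc(OC)cc3)CC2)C(=O)Nc2ccccc21`: 25.4 nM

Compound 3 gives the highest number of the three in this assay, so it is the weakest inhibitor measured here. Its nearest neighbour in value is compound 2, and the furthest is compound 1; both gaps lie beyond the scatter.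

The new compound is compound 4 `CCC1(CCCCN2CCN(c3ccc(F)cc3)CC2)C(=O)Nc2ccccc21`. It arises from compound 3 by a single change: fluoro in place of methoxy on an aromatic carbon. Among the compounds with values here, only one measured step bears on this position: a 62-fold higher number from compound 1 to compound 3 (1.79 log units; beyond the scatter). That step replaced 3-chlorophenyl by 4-methoxyphenyl and made the number much higher, so the methoxy-bearing ring is associated with the weakest result seen. Compound 2 already carries the 4-fluorophenyl group of compound 4, though its core also carries a fluoro, and its value sits far below that of compound 3.

Taken together, removing the methoxy in favour of fluoro is expected to give a clearly lower number, a step of about a 13-fold lower number from compound 3 to compound 4 (1.10 log units; beyond the scatter). Compound 4 is therefore estimated at 2 nM, with a likely range from 0.7 nM to 8 nM.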

Compound 4, inhibition constant: 0.43 nM
Compound 4: the middle estimate sits 4.7-fold (0.67 log units) above what was measured; the whole stated range lies above it.
By their numbers in this assay, from the lowest: compounds 1 and 4 (each within the scatter of the next); then compound 2; then compound 3.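

Measured in this assay with nothing else in the molecule altered, fluoro in place of methoxy gives a 59-fold lower number from compound 3 to compound 4 (1.77 log units; beyond the scatter) and so ties the high number of compound 3 to the methoxy group itself. The earlier step to compound 3 had changed both the substituent and its place on the ring, so it could not do this. The 4-fluorophenyl and 3-chlorophenyl groups cannot be told apart here, since the comparison gives a 1.0-fold higher number from compound 1 to compound 4 (0.02 log units; within the scatter) and shows that a group at this ring position does not in itself bring a high number, while removing the fluoro from the core gives only a 3.5-fold lower number from compound 2 to compound 4 (0.54 log units; beyond the scatter) and so counts for much less than the methoxy-to-fluoro change.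

Nothing shown gives a reason for the size of the methoxy step. Going by these compounds, it also remains open whether a hydroxyl, a methyl, an ethoxy or an amine on this same ring carbon would give a number close to that of the fluoro compound or close to that of the methoxy compound.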